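Replacing the aryl group on the anilino nitrogen of compound 2

A few compounds are considered here, and "the series" means these few. Any claim that something is new, unique, unknown or untested is made for them only; others in the source may bear on it.

Measured compounds:
Compound 1, `COc1cc2ncnc(Nc3ccc(OC(F)(F)F)cc3)c2cc1OCCCSc1nc2ccccc2o1`, in a functional assay on MCF7 cells (Homo sapiens) for cytotoxicity, read by MTT assay, with a stated time of 24 h (on this read-out lower numbers stand for stronger inhibition and higher numbers for weaker inhibition), gives 9080 nM.
Compound 2, `CCc1cc(Br)ccc1Nc1ncnc2cc(OC)c(OCCCSc3nc4ccccc4o3)cc12`, in this assay gives 17300 nM.

Within the data shown here, compound 2 stands alongside compound 1 rather than apart from it: the only measured step, a 1.9-fold higher number from compound 1 to compound 2 (0.28 log units; within the scatter), exchanged the aryl group on the same nitrogen and stayed within the scatter. Compound 3, `COc1ccc(Nc2ncnc3cc(OC)c(OCCCSc4nc5ccccc5o4)cc23)cc1`, has not yet been measured. It differs from compound 2 by 4-methoxyphenyl in place of 4-bromo-2-ethylphenyl on a nitrogen on an aromatic ring. Among the measured compounds shown here, the one step that bears on this change is a 1.9-fold higher number from compound 1 to compound 2 (0.28 log units; within the scatter), which is the same kind of exchange at the same place and moved the number by no more than the scatter. The same is therefore expected here in this assay: a step of a 1.4-fold lower number from compound 2 to compound 3 (0.16 log units; within the scatter) that does not rise beyond the scatter. Compound 3 is estimated at 12000 nM, with a range from 4000 nM to 36000 nM.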

Compound 3, half-maximal inhibitory concentration: 13100 nM
Compound 3: the middle estimate sits 1.1-fold (0.04 log units) below what was measured; measured number inside the range.
By their numbers in this assay, from the lowest: compounds 1, 3 and 2 (each within the scatter of the next).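

In this assay, the move to 4-methoxyphenyl gives a 1.3-fold lower number from compound 2 to compound 3 (0.12 log units; within the scatter) and, as a change of methyl for trifluoromethyl on the oxygen, a 1.4-fold higher number from compound 1 to compound 3 (0.16 log units; within the scatter) and neither step leaves the scatter. With a third aryl group now measured on this nitrogen, no exchange there has moved the number beyond the scatter, whether the ring carries bromine and ethyl, trifluoromethoxy or methoxy. No measurement at hand speaks to the reason for this result.

On these data alone, what an aryl ring bearing an amine or a carboxylic acid would do at this nitrogen stays open. All three compounds also share the same core and side chain, so the effect of a longer chain on the core cannot be told from them.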